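A few compounds are considered here, and "the series" means these few. Any claim that something is new, unique, unknown or untested is made for them only; others in the source may bear on it.

In a functional assay on A2780 cells (Homo sapiens) for cytotoxicity, read by MTT assay, with a stated time of 48 h (on this read-out higher numbers stand for weaker inhibition and lower numbers for stronger inhibition), compound 1 `CC(=O)OC1=C(c2cccc3cccnc23)Oc2cc3ccccc3cc2-n2cccc21` gives 76 nM and compound 2 `CC(=O)OC1=C(c2cc(C)nc3ccccc23)Oc2cc3ccccc3cc2-n2cccc21` gives 285 nM as the higher of the two numbers. Within the data shown here, the only measured step, a 3.8-fold higher number from compound 1 to compound 2 (0.57 log units; beyond the scatter), replaces a whole group on a double-bonded ring carbon. Compound 3 `CCc1cc(C2=C(OC(C)=O)c3cccn3-c3cc4ccccc4cc3O2)c2ccccc2n1` differs from compound 2 by methyl in place of hydrogen on a saturated chain carbon bound to an aromatic carbon, which is methyl to ethyl, a much smaller change. Among the measured compounds shown here, no measured step covers this kind of change, so that modest step offers only a loose guide, and compound 2 at 285 nM serves as the anchor. An a 1.1-fold higher number from compound 2 to compound 3 (0.02 log units; within the scatter) is expected, so no shift beyond the scatter is foreseen in this assay here. Compound 3 is estimated at 300 nM with a range from 120 nM to 700 nM in this read-out.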

Compound 3, half-maximal inhibitory concentration: 1000 nM
Estimate against measurement, compound 3: 3.3-fold (0.52 log units) below, outside the stated range (above it).
By their numbers in this assay, from the lowest: compound 1; then compound 2; then compound 3.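

In this assay, going from methyl to ethyl on a saturated chain carbon bound to an aromatic carbon is not a silent change: the number rises beyond the scatter, with a 3.5-fold higher number from compound 2 to compound 3 (0.55 log units; beyond the scatter). This single added methyl gives a step of the same modest class as the exchange of a whole group, a 3.8-fold higher number from compound 1 to compound 2 (0.57 log units; beyond the scatter). Nothing available explains the rise.

Open, from the compounds shown here alone, is whether a longer chain such as propyl continues in the same direction. Also open, going by these compounds, is how an amine or a hydroxyl on this chain would read.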